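Working notes: compound 4 weighed against compound 1

A few compounds are considered here, and "the series" means these few. Any claim that something is new, unique, unknown or untested is made for them only; others in the source may bear on it.

Compound 1 `CN(C(=O)NC(=O)c1ccc(F)c(F)c1)c1nc(C(F)(F)F)c(C(=O)N/N=C/c2ccc(C(F)(F)F)cc2)s1` serves as the reference point of this small set. In a functional assay on HepG2 cells (Homo sapiens) for inhibition, read by MTT assay, with a stated time of 72 h (on this read-out lower numbers stand for stronger inhibition and higher numbers for weaker inhibition), compound 1 gives 6.26 ug/mL, the lowest of the two numbers on hand. In this assay compound 2 `CN(C(=O)NC(=O)c1ccc(Cl)cc1Cl)c1nc(C(F)(F)F)c(C(=O)N/N=C/c2cccc(C(F)(F)F)c2)s1` gives 11.2 ug/mL; the two numbers sit within the scatter of each other, so no order between compound 1 and compound 2 is claimed. Compound 3 `CNc1nc(C)c(C(=O)N/N=C/c2ccccc2C(F)(F)F)s1` reaches only a limit: in this assay compound 3 gives > 100 ug/mL, which is a limit of the assay and not a number (the limit of > 100 ug/mL in this assay, at which 1 of the 3 values shown sits).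

Compound 4 `CN(C(=O)NC(=O)c1cccc(C(F)(F)F)c1)c1nc(C(F)(F)F)c(C(=O)N/N=C/c2ccc(C(F)(F)F)cc2)s1` differs from compound 1 in a single place: 3-(trifluoromethyl)phenyl in place of 3,4-difluorophenyl on a carbonyl carbon. For the measured compounds named here, no measured pair carries this change, so its size can only be guessed. Both compound 1 and compound 2 keep halogenated aryl groups on that carbonyl and land close together, which suggests the step from compound 1 to compound 4 should stay within the scatter, with no clear direction. The expected step is a 1.2-fold higher number from compound 1 to compound 4 (0.08 log units; within the scatter). For compound 4 the estimated value in this assay is 7.5 ug/mL, with a range from 3 ug/mL to 18 ug/mL.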

Compound 4, half-maximal inhibitory concentration: 7.71 ug/mL
The estimate for compound 4 lay 1.0-fold (0.01 log units) below the measured number; low and high end bracket the measured number.
By their numbers in this assay, from the lowest: compounds 1, 4 and 2 (each within the scatter of the next). At a limit, above all of these: compound 3.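

For the compounds shown here, on the carbonyl carbon, 3-(trifluoromethyl)phenyl in place of 3,4-difluorophenyl is the first single change in this set that can be read on its own: in this assay it gives a 1.2-fold higher number from compound 1 to compound 4 (0.09 log units; within the scatter) and so leaves the number within the scatter. This position therefore takes the swap, with 10 heavy atoms entering for 8, without a step beyond the scatter; compound 2 could not show this, as it differs from compound 1 in more than one place. Nothing on hand gives a cause for this step.

Among the compounds that keep this carbonyl, only halogen-bearing phenyl groups stand on it, so the effect of an amine, a carboxylic acid or a longer alkyl chain there remains open. Compound 3 differs from compound 1 in more than one place, so its limit cannot be tied to any single change.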